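Replacing the Amino Group on a Selenium-Bearing Core

The source may hold more compounds than are shown below. What is called first, only, known or untested is meant among the compounds shown, and "the series" means these compounds.

Compound 1 `C[Se]c1nc(N)c2ccccc2n1` carries an amino group on its fused core. In a functional assay on MCF7 cells (Homo sapiens) for cytotoxicity, read by MTT assay, with a stated time of 72 h (a lower number here means a stronger inhibitor of growth, a higher number a weaker inhibitor of growth), compound 1 gives > 100000 nM, which is a limit of the assay rather than a number. Compound 2 `Nc1nc([SeH])nc2ccccc12` differs from it by hydrogen in place of methyl on a selenium. In this assay compound 2 gives > 100000 nM, again a limit. The step that the two limits leave unreadable from compound 1 to compound 2 therefore cannot be read, since both values sit at the limit of > 100000 nM in this assay, at which 2 of the 2 values shown sit. Compound 3 `C[Se]c1nc([Se]C)c2ccccc2n1` has not yet been measured. It differs from compound 1 by a group of 2 heavy atoms (1 carbon, 1 selenium; no ring) in place of one nitrogen atom, on an aromatic carbon. Within the data shown here, no measured step bears directly on this change; the only step available is unreadable, and every value shown is a limit. The expected step of a number no higher from compound 1 to compound 3 (the limit leaves the size open) is thus not readable beyond the scatter. Compound 3 is estimated to give 100000 nM in this assay, within 30000 nM to 300000 nM, and is expected most likely to be reported as a limit again.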

Compound 3, concentration for total growth inhibition: 50700 nM
Estimate against measurement, compound 3: 2.0-fold (0.29 log units) above, and the stated range covers the measured number.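

Among these compounds, compound 3 gives 50700 nM in this assay and is the first compound here to yield a number rather than a limit. Putting the group of 2 heavy atoms (1 carbon, 1 selenium; no ring) in place of the amino group on this aromatic carbon gives an at least 1.9-fold lower number from compound 1 to compound 3 (0.29 log units; that floor lies within the scatter) and so shows that a value can be read on the shared core without the amino group. The true size of the step stays open, since it rests on a limit for compound 1: the limit of > 100000 nM in this assay, at which 2 of the 3 values shown sit.

On these data alone, whether the selenium atom at this aromatic carbon matters, or whether a methylthio group there would serve as well, remains open. So does the effect of a longer chain on selenium, such as ethyl, or of a dimethylamino group at this carbon.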